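From 2-bromobenzyl to 3-bromobenzyl: little change expected

The compounds below may be only part of what the source reports. "The series", "measured", "known", "first", "only" and "open" are said of these compounds alone.

In a functional assay on HepG2 cells (Homo sapiens) for antiproliferative activity, read by MTT assay, with a stated time of 48 h (on this read-out lower numbers stand for stronger inhibition and higher numbers for weaker inhibition), compound 3 (`Brc1ccccc1CSc1nnc(-c2cnccn2)n1-c1ccccc1`) gives 11600 nM and stands level with compound 1 (`Fc1ccc(CSc2nnc(-c3cnccn3)s2)cc1`) at 10100 nM and compound 2 (`c1ccc(CSc2nnc(-c3cnccn3)s2)cc1`) at 11400 nM on this measure, all three lying within the usual scatter. Compound 4 (`Brc1cccc(CSc2nnc(-c3cnccn3)n2-c2ccccc2)c1`) has 3-bromophenyl in place of 2-bromophenyl on a saturated chain carbon bound to a sulfur with the same atoms joined differently. Within the data shown here, the only measured step, hydrogen in place of fluoro on an aromatic carbon, gave a 1.1-fold higher number from compound 1 to compound 2 (0.05 log units; within the scatter) and is a different change. Among the measured compounds shown here, no measured pair moves a bromine, so no step beyond the scatter is expected in this assay and no direction is favoured. The estimate therefore means an expected 1.1-fold lower number from compound 3 to compound 4 (0.02 log units; within the scatter) here. Compound 4 is expected at 11000 nM in a range of 5000 nM to 25000 nM by this estimate.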

Compound 4, half-maximal inhibitory concentration: 10600 nM
Beside the measured number, compound 4's estimate is 1.0-fold (0.02 log units) above it; low and high end bracket the measured number.
By their numbers in this assay, from the lowest: compounds 1, 4, 2 and 3 (each within the scatter of the next).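

Among these compounds, this is the first measured pair to test where the bromine sits on the benzyl group: going from 2-bromobenzyl to 3-bromobenzyl gives a 1.1-fold lower number from compound 3 to compound 4 (0.04 log units; within the scatter) in this assay. At this place, on a saturated chain carbon bound to a sulfur, the two placements of the bromine cannot be told apart on this read-out. Nothing available explains this result. Still open, from the compounds shown here alone, is whether a different group in place of the bromine, such as a carboxylic acid or an amine, would move the number beyond the scatter.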